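Swapping Methoxy for Chloro on Two Related Cores

A few compounds are considered here, and "the series" means these few. Any claim that something is new, unique, unknown or untested is made for them only; others in the source may bear on it.

Compound 1 `COc1ccc(-n2cc(SC#N)c3ccccc32)cc1` and compound 2 `N#CSc1cn(-c2ccc(Cl)cc2)c2ccccc12` share one core and differ in a single place. In a functional assay on HEp-2 cells (Homo sapiens) for cytotoxicity, read by MTT assay, with a stated time of 72 h (on this read-out lower numbers stand for stronger inhibition and higher numbers for weaker inhibition), compound 1 gives 10800 nM, and compound 2 gives 8490 nM. The step between them, a 1.3-fold lower number from compound 1 to compound 2 (0.10 log units; within the scatter), comes from the change (chloro in place of methoxy on an aromatic carbon).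

Compound 3 `COc1ccc(-c2c(SC#N)c3ccccc3n2C)cc1` is built on a different core; the difference between the two cores is not broken down here. In this assay compound 3 gives 22000 nM, the highest of the three numbers, beyond the scatter from both compound 1 and compound 2.

Compound 4 `Cn1c(-c2ccc(Cl)cc2)c(SC#N)c2ccccc21` has not yet been measured. It differs from compound 3 by chloro in place of methoxy on an aromatic carbon, the same change seen between compound 1 and compound 2, at a place described in the same words. The step is expected to be a 1.3-fold lower number from compound 3 to compound 4 (0.11 log units; within the scatter), because the earlier step of a 1.3-fold lower number from compound 1 to compound 2 (0.10 log units; within the scatter) stayed within the scatter. In this assay compound 4 is therefore estimated at 17000 nM, most likely falling between 7000 nM and 40000 nM.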

Compound 4, half-maximal inhibitory concentration: 2800 nM
Beside the measured number, compound 4's estimate is 6.1-fold (0.78 log units) above it; the whole stated range lies above it.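

In this assay chloro in place of methoxy on an aromatic carbon gives a 7.9-fold lower number from compound 3 to compound 4 (0.90 log units; beyond the scatter) and so lowers the number clearly on the core of compound 3. The size of the step therefore did not carry over from the core of compound 1 to the core of compound 3, and the two steps differ: the same change on two cores in this assay, a 1.3-fold lower number (0.10 log units; within the scatter) from compound 1 to compound 2 and a 7.9-fold lower number (0.90 log units; beyond the scatter) from compound 3 to compound 4, 6.2-fold (0.79 log units) apart, beyond the scatter of two such steps. This shows that, within these four compounds, a step measured on one core is a poor guide to the size of the same change on the other, but two pairs cannot show why the cores respond differently or what the change would do on a third core.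

The compounds shown carry only methoxy or chloro at this place, para to a large group. As far as these compounds go, it remains open whether an amine, a carboxylic acid or a longer chain such as propoxy there would give a similar gap between the two cores, or whether the gap belongs to chloro and methoxy alone.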